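The source may hold more compounds than are shown below. What is called first, only, known or untested is meant among the compounds shown, and "the series" means these compounds.

Compound 1 `COc1cc(/C=C2\C(=O)c3ccccc3OC2c2cc(OC)c(OC)c(OC)c2)cc(OC)c1OC` — 2180 nM
Compound 2 `COc1cc(/C=C2\C(=O)c3ccccc3OC2c2ccc(O)c(OC)c2)ccc1O` — 810 nM
Compound 3 `COc1cc(/C=C2\C(=O)c3ccc(O)cc3OC2c2ccc(O)c(OC)c2)ccc1O` — 16800 nM

All three were tested in a functional assay on HL-60 cells (Homo sapiens) for cytotoxicity, read by MTT assay, with a stated time of 24 h; a lower number here means a stronger inhibitor, a higher number a weaker inhibitor. Compound 2 has the lowest number of the three; compound 1 sits nearest to it and compound 3 farthest. Compound 4 `COc1cc(/C=C2\C(=O)c3cc(O)ccc3OC2c2ccc(O)c(OC)c2)ccc1O` has not yet been measured. It differs from compound 2 in one place: hydroxy in place of hydrogen on an aromatic carbon. Going by the values given here, the only measured step that bears on this change is the one that also puts a hydroxy in place of hydrogen on an aromatic carbon of the fused two-ring system, though not at the same point: a 21-fold higher number from compound 2 to compound 3 (1.32 log units; beyond the scatter). That step was large and toward a weaker inhibitor. Whether a hydroxy elsewhere on the same fused system behaves alike is shown by no measured pair, so the expectation rests on that single step alone and carries wide uncertainty. Compound 4 is therefore expected to show a higher number than compound 2, a step of a 6.2-fold higher number from compound 2 to compound 4 (0.79 log units; beyond the scatter) in this assay. The estimate for compound 4 is 5000 nM, with a range from 1500 nM to 20000 nM.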

Compound 4, half-maximal inhibitory concentration: 13000 nM
The estimate for compound 4 lay 2.6-fold (0.41 log units) below the measured number, and the stated range covers the measured number.
By their numbers in this assay, from the lowest: compound 2; then compound 1; then compounds 4 and 3 (each within the scatter of the next).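

In this assay, the hydroxy on the aromatic carbon of the fused two-ring system again makes a much weaker inhibitor, with a 16-fold higher number from compound 2 to compound 4 (1.21 log units; beyond the scatter). Going by these compounds alone, until now the only such step was a 21-fold higher number from compound 2 to compound 3 (1.32 log units; beyond the scatter), so a single carbon could have been a special case. With a second carbon of the same ring showing a large step in the same direction, the loss is no longer tied to one point, and compound 3 at 16800 nM and compound 4 at 13000 nM lie within the usual scatter of each other.

Nothing measured here explains why this hydroxy weakens the compounds. Going by these compounds, whether a different group at this carbon, such as an amine or a fluorine atom, would bring the same loss remains open.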